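The source may report more compounds than this note shows. Statements on the series, on what has been measured and on what is new or still open speak of the compounds shown alone.

Measured so far:
Compound 1 `COc1cccc(NC(=S)N/N=C/c2ccc3ccccc3n2)c1` gives 74500 nM in a functional assay on HeLa cells (Homo sapiens) for antiproliferative activity, read by sulforhodamine B assay, with a stated time of 72 h; on this read-out higher numbers stand for weaker inhibition and lower numbers for stronger inhibition.
Compound 2 `CN(C)C(=S)N/N=C/c1ccc2ccccc2n1` gives 90 nM in this assay.

Compound 1 stands at the highest of the two numbers, and compound 2 sits far below it, a gap well beyond the scatter. Compound 3 `Fc1ccc(NC(=S)N/N=C/c2ccc3ccccc3n2)cc1` is not yet measured. It differs from compound 1 in one place: 4-fluorophenyl in place of 3-methoxyphenyl on an amide-type nitrogen. Among the measured compounds shown here, no step between measured compounds tells how this change acts. Compound 3 is therefore expected to stay near compound 1 in this assay, with a step of a 1.5-fold lower number from compound 1 to compound 3 (0.17 log units; within the scatter) that is not clearly beyond the scatter. Compound 3 is estimated at 50000 nM, within a range from 10000 nM to 200000 nM.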

Compound 3, half-maximal inhibitory concentration: 33200 nM
Compound 3: the middle estimate sits 1.5-fold (0.18 log units) above what was measured, and the stated range covers the measured number.
By their numbers in this assay, from the lowest: compound 2; then compound 3; then compound 1.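

In this assay, among the compounds shown here, replacing 3-methoxyphenyl with 4-fluorophenyl on the amide-type nitrogen gives a 2.2-fold lower number from compound 1 to compound 3 (0.35 log units; beyond the scatter), the first reading of a change at this position. The step is modest, so this exchange of aryl groups shifts the number measurably while both compounds stay in the same high range. Nothing available explains the shift. The compounds shown do not separate the effect of the substituent from that of its location on the ring. Also open, from the compounds shown here alone, is how a plain phenyl, or a phenyl carrying an amine or a carboxylic acid, would read at this nitrogen.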